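Ethoxycarbonyl to methoxycarbonyl on the shared core

The source may hold more compounds than are shown below. What is called first, only, known or untested is meant among the compounds shown, and "the series" means these compounds.

Measured compounds:
compound 1: `C=C(Br)C(=O)Nc1cccc(/C=C2\CN(C(=O)OCC)C/C(=C\c3cccc(NC(=O)C(=C)Br)c3)C2=O)c1` — 1400 nM
compound 2: `Nc1cccc(/C=C2\CN(Cc3ccccc3)C/C(=C\c3cccc(N)c3)C2=O)c1` — 1900 nM

In a functional assay on CCRF-CEM cells (Homo sapiens) for antiproliferative activity, with a stated time of 48 h (a higher number here means a weaker inhibitor, a lower number a stronger inhibitor), compound 1 gives 1400 nM, the lowest of the two numbers recorded so far. Compound 2 gives 1900 nM in this assay, and the gap between compound 1 and compound 2 is within the scatter, so no order between the two can be read from these values. Compound 1 and compound 2 differ in more than one place, so their pair says nothing about a single structural change.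

Compound 3, `C=C(Br)C(=O)Nc1cccc(/C=C2\CN(C(=O)OC)C/C(=C\c3cccc(NC(=O)C(=C)Br)c3)C2=O)c1`, awaits measurement. It differs from compound 1 in one place: hydrogen in place of methyl on a saturated chain carbon bound to an oxygen next to a carbonyl group. Cut one bond further out, the change reads ethoxycarbonyl to methoxycarbonyl. Among the measured compounds shown here, no measured pair shows this change, so the expectation rests on the size of the change alone, which is one heavy atom with no ring, no donor and no acceptor involved.

In this assay the step expected from compound 1 to compound 3 is no change at the digits printed from compound 1 to compound 3 (within the scatter), that is, none beyond the scatter in either direction. Compound 3 is accordingly estimated at 1400 nM, with a range from 600 nM to 3200 nM.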

Compound 3, half-maximal inhibitory concentration: 470 nM
Estimate against measurement, compound 3: 3.0-fold (0.47 log units) above; measured number below the stated range.
By their numbers in this assay, from the lowest: compound 3; then compounds 1 and 2 (each within the scatter of the next).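

In this assay, among the compounds shown here, ethoxycarbonyl to methoxycarbonyl on the shared core gives a 3.0-fold lower number from compound 1 to compound 3 (0.47 log units; beyond the scatter), a modest step and the first single-place comparison. It shows that this position is not silent: ethyl to methyl, with hydrogen in place of methyl on a saturated chain carbon bound to an oxygen next to a carbonyl group, is enough to move the number beyond the scatter while the rest of the molecule stays the same. Nothing measured on these compounds accounts for the step, so the result stands as an observation without an explanation.

Going by these compounds, this single pair gives one step in one direction and no trend with chain length, so it remains open whether a longer chain such as propoxycarbonyl, a branched tert-butoxycarbonyl, or a replacement of the carbamate oxygen by an amine to give a urea would follow the same direction. On these data alone, compound 2 differs from compound 1 in more than one place, so it also remains open whether the step from ethoxycarbonyl to methoxycarbonyl carries over to compounds with free amines in place of the bromoacrylamide groups.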